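The source may report more compounds than this note shows. Statements on the series, on what has been measured and on what is new or still open speak of the compounds shown alone.

Compound 1 `CCO/N=C(\CCN1CCN(c2ccc(OC)cc2)CC1)c1ccccc1` is read in a functional assay on HEK293 cells with D(4) dopamine receptor (Homo sapiens) as the target, read by FLIPR; on this read-out higher numbers stand for an effect only at larger amounts of compound and lower numbers for an effect already at smaller amounts; there compound 1 gives only a limit, > 10000 nM. Compound 2 `CCO/N=C(\CCN1CCN(c2cccc(OCC)c2)CC1)c1ccccc1` carries a 3-ethoxyphenyl on the ring amine nitrogen instead, and in this assay compound 2 gives 347 nM. Among the measured compounds shown here, the one measured step, an at least 28-fold lower number from compound 1 to compound 2 (1.45 log units; beyond the scatter), is large. For the measured compounds named here, compound 2 therefore stands as the only compound with a number in this assay; the other value is a limit (the limit of > 10000 nM in this assay, at which 1 of the 2 values shown sits). Compound 3 `CCO/N=C(\CCN1CCN(c2ncccc2C#N)CC1)c1ccccc1` differs from compound 2 by 3-cyanopyridin-2-yl in place of 3-ethoxyphenyl on an amine nitrogen in a ring. The step from compound 1 to compound 2 is the only one that bears on this change, and it shows that the aryl group on the ring nitrogen can move the read-out by a large amount, in either direction. For compound 3 a moderate step toward a higher number is expected, a 2.6-fold higher number from compound 2 to compound 3 (0.41 log units; beyond the scatter), and compound 3 is estimated at 900 nM, with a range from 150 nM to 6000 nM.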

Compound 3, half-maximal effective concentration: 139 nM
Estimate against measurement, compound 3: 6.5-fold (0.81 log units) above; the whole stated range lies above it.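

In this assay, among the compounds shown here, the earlier compounds carried only a 3-ethoxyphenyl or a 4-methoxyphenyl on the ring amine nitrogen; compound 3 shows that this place also takes a 3-cyanopyridin-2-yl, a six-membered aromatic ring with a hetero atom, and that the swap gives a 2.5-fold lower number from compound 2 to compound 3 (0.40 log units; beyond the scatter). The wider comparison gives an at least 71-fold lower number from compound 1 to compound 3 (1.85 log units; beyond the scatter), and the size of this step is only a bound. The value of compound 1 is a limit and not a number: the limit of > 10000 nM in this assay, at which 1 of the 3 values shown sits.

Two things change at once in compound 3, the ring hetero atom and the nitrile, so the compounds shown do not tell which of them goes with the step. On these data alone, a pyridin-2-yl without the nitrile or a 3-cyanophenyl would separate the two, and an amide in place of the nitrile remains open as well.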